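A few compounds are considered here, and "the series" means these few. Any claim that something is new, unique, unknown or untested is made for them only; others in the source may bear on it.

Of the compounds shown here, two of this set have been measured in a functional assay on RAW264.7 cells (Mus musculus) for cytotoxicity, read by MTT assay, with a stated time of 24 h; on this read-out higher numbers stand for weaker inhibition and lower numbers for stronger inhibition. Compound 1, `O=S(=O)(O)OCCCCCCCCCC[Se]c1ccccc1`, gives only a limit of this assay, > 100000 nM. Compound 2, `O=S(=O)(O)OCCCCCCCCCC[Te]c1ccccc1`, gives 5320 nM in this assay. For the measured compounds named here, the single measured step, an at least 18-fold lower number from compound 1 to compound 2 (1.27 log units; beyond the scatter), is the only guide to the series so far. Compound 1 sits at the limit, (the limit of > 100000 nM in this assay, at which 1 of the 2 values shown sits), so the size of that step is known only as a bound. Going by the values given here, compound 2 therefore stands as the sole numerical value in this assay, the remaining entry being a limit rather than a number.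

Compound 3, `O=S(=O)(O)OCCCCCCCCC[Te]c1ccccc1`, differs from compound 2 by sulfooxy in place of (sulfooxy)methyl on a saturated chain carbon, nine bonds along the chain from a tellurium atom. Among the compounds with values here, no measured step bears on this change: the one step measured exchanges the selenium-bearing aromatic group for the tellurium-bearing one and says nothing about the sulfooxy in place of (sulfooxy)methyl change on the chain. The expectation for compound 3 in this assay is therefore a step of a 1.0-fold lower number from compound 2 to compound 3 (0.00 log units; within the scatter), lying within the scatter. Compound 3 is estimated at 5300 nM, in a range from 2000 nM to 14000 nM.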

Compound 3, half-maximal inhibitory concentration: 4670 nM
For compound 3 the middle estimate is 1.1-fold (0.05 log units) above the measured one; the measured number falls inside the stated range.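

In this assay the step is a 1.1-fold lower number from compound 2 to compound 3 (0.06 log units; within the scatter), so compound 2 and compound 3 cannot be told apart on this read-out. For the compounds shown here, this is the first reading of the chain itself: the earlier step exchanged only the selenium-bearing aromatic group for the tellurium-bearing one, whereas this one shows that sulfooxy in place of (sulfooxy)methyl, on a saturated chain carbon, nine bonds along the chain from a tellurium atom, gives a number that stays within the scatter in this one case. Nothing on record bears on how this chain change acts in the assay.

Going by these compounds, one pair cannot show whether the same holds further along the series, and it remains open whether a longer chain or a much shorter one would read the same as compound 2 and compound 3. Also open, on these data alone, is whether a carboxylic acid or a phosphate in the place of the sulfooxy group would keep the number, and how the selenium counterpart of compound 3 would read.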